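Replacing dichlorophenyl with methoxyphenyl on the shared core

This account rests on a few compounds, and the source may have more. Where it says the series, first, only, none or still open, it means among the compounds named here.

The series rests on a shared core, and three of its members have been tested in a functional assay on NCI-H322M cells (Homo sapiens) for inhibition, read by sulforhodamine B assay, with a stated time of 48 h; a higher number here means that more compound is tolerated, a lower number that less compound is tolerated. Compound 1 `CCOC(=O)[C@H](CCC(=O)O)NC(=O)c1ccc(CNc2nc3cc(N)cc(N)c3nc2-c2ccccc2)cc1` reaches only the limit of this assay, reported as < 100000 nM. Compound 3 `CCOC(=O)[C@H](CCC(=O)O)NC(=O)c1ccc(Sc2nc3cc(N)cc(N)c3nc2-c2ccccc2)cc1` likewise stops at the limit, given as < 100000 nM. Among the compounds with values here, compound 2 `Nc1cc(N)c2nc(-c3ccccc3)c(NCc3ccc(Cl)c(Cl)c3)nc2c1` is therefore the only member with a proper number in this assay, where compound 2 gives 69200 nM. Where it stands against the others cannot be said, since the two companions sit at the limit of < 100000 nM in this assay, at which 2 of the 3 values shown sit, and no step between measured compounds is available.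

Compound 4 `COc1ccc(CNc2nc3cc(N)cc(N)c3nc2-c2ccccc2)cc1` has not yet been measured. It differs from compound 2 in one place: 4-methoxyphenyl in place of 3,4-dichlorophenyl on a saturated chain carbon bound to a nitrogen on an aromatic ring. Within the data shown here, with no measured step of this kind to lean on, the step from compound 2 to compound 4 in this assay is expected to be small, a 1.2-fold higher number from compound 2 to compound 4 (0.06 log units; within the scatter), in the direction of slightly more compound being tolerated, and it may well fall within the usual scatter. Compound 4 is expected to give about 80000 nM, with a likely range from 30000 nM to 100000 nM, and a fair chance that only the limit is reported.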

Compound 4, concentration lethal to 50% of the cells: < 100000 nM
Compound 4: only a limit was reported; the forecaster's own chance of this, stated with the estimate: 45%; the middle value does not contradict the limit.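

In this assay, within the data shown here, compound 4 gives < 100000 nM as a limit and not a number, and no step from compound 2 to compound 4 can be read. As far as these compounds go, whether 4-methoxyphenyl in place of 3,4-dichlorophenyl on a saturated chain carbon bound to a nitrogen on an aromatic ring moves the number in this assay at all, and in which direction, stays open.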